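A few compounds are considered here, and "the series" means these few. Any claim that something is new, unique, unknown or untested is made for them only; others in the source may bear on it.

Compound 1 `COc1ccc(C2C(C#N)=C(N)N(c3ccc(S(N)(=O)=O)cc3)C3=C2C(=O)CCC3)cc1` gives 30% in a functional assay on Ehrlich cells (Mus musculus) for antiproliferative activity, read by trypan blue exclusion, with a stated time of 2 h, tested at 10 ug/mL; a higher number here means a stronger effect of the compound at the concentration tested, a lower number a weaker effect.
Compound 2 `N#CC1=C(N)N(c2ccc(S(N)(=O)=O)cc2)C2=C(C(=O)CCC2)C1c1ccco1` gives 0% in this assay.

Among the compounds with values here, compound 2 stands lowest of the two numbers; the only measured step, a number 30 percentage points lower from compound 1 to compound 2 (beyond the scatter), lies beyond the scatter. Compound 3 `Cc1ccoc1C1C(C#N)=C(N)N(c2ccc(S(N)(=O)=O)cc2)C2=C1C(=O)CCC2` differs from compound 2 by methyl in place of hydrogen on an aromatic carbon. Within the data shown here, no measured step bears directly on this change: the single step exchanges the whole aryl group on the saturated ring carbon, not a substituent of the furan-2-yl group. Little shift from compound 2 is therefore expected. Compound 3 is estimated at 5% in this assay, within 0% to 25%. The expected step of a number 5 percentage points higher from compound 2 to compound 3 (within the scatter) is within the scatter.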

Compound 3, a percentage reported as activity, at one concentration (the size of the read-out at that concentration, not a potency): 2%
For compound 3 the middle estimate is 3 percentage points above the measured one; measured number inside the range.
By their numbers in this assay, from the lowest: compounds 2 and 3 (each within the scatter of the next); then compound 1.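

Methyl in place of hydrogen on an aromatic carbon of the furan, next to the ring atom that bears a large group, gives a number 2 percentage points higher from compound 2 to compound 3 (within the scatter), so compound 2 and compound 3 cannot be told apart at this position. The exchange of 4-methoxyphenyl for 3-methylfuran-2-yl gives a number 28 percentage points lower from compound 1 to compound 3 (beyond the scatter), so the gap to compound 1 persists with the methyl present.

Open, going by these compounds, is whether an amine or a carboxylic acid on this furan carbon would separate from hydrogen, and whether a hydroxyl in place of the methoxy would hold the number of compound 1. No measured evidence bears on the reason for these numbers.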